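Swapping dichlorophenyl for trifluoromethylphenyl on a shared core

The compounds below may be only part of what the source reports. "The series", "measured", "known", "first", "only" and "open" are said of these compounds alone.

Of the compounds shown here, three have been measured in a functional assay on MOLT-4 cells (Homo sapiens) for inhibition, read by sulforhodamine B assay, with a stated time of 48 h; on this read-out higher numbers stand for weaker inhibition of growth and lower numbers for stronger inhibition of growth. Compound 1 `O=C(Nc1cccc(-n2cc(-c3ccncc3)c(-c3ccc(Cl)c(O)c3)n2)c1)Nc1ccc(Cl)c(Cl)c1` gives 1380 nM. Compound 2 `COc1cc(-c2nn(-c3cccc(NC(=O)c4cccc(C(F)(F)F)c4)c3)cc2-c2ccncc2)ccc1Cl` gives 2010 nM, and compound 3 `COc1cc(-c2nn(-c3cccc(NC(=O)c4ccccc4)c3)cc2-c2ccncc2)ccc1Cl` gives 701 nM. On these numbers compound 1 stands second highest of the three; its gap to compound 2 and its gap to compound 3 both lie within the usual scatter, so no order among them can be claimed. For the measured compounds named here, the only step between two measured compounds that differ in one place is a 2.9-fold lower number from compound 2 to compound 3 (0.46 log units; beyond the scatter), a modest step beyond the scatter, in which removing a trifluoromethyl group lowered the number.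

Compound 4 `O=C(Nc1cccc(-n2cc(-c3ccncc3)c(-c3ccc(Cl)c(O)c3)n2)c1)Nc1cccc(C(F)(F)F)c1` differs from compound 1 by 3-(trifluoromethyl)phenyl in place of 3,4-dichlorophenyl on an amide-type nitrogen. Going by the values given here, no measured step changes exactly this group on this nitrogen, so the step from compound 2 to compound 3 is the only guide, and it bears only loosely, since it compares trifluoromethyl with hydrogen rather than with 3,4-dichlorophenyl. Given that in that step the trifluoromethyl-bearing compound 2 gave the higher number 2010 nM, a small rise in the number is expected for compound 4, though possibly within the scatter. The expected step is a 1.4-fold higher number from compound 1 to compound 4 (0.14 log units; within the scatter). Compound 4 is therefore estimated at 1900 nM, with a range from 700 nM to 5000 nM.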

Compound 4, concentration for 50% growth inhibition: 1920 nM
Estimate against measurement, compound 4: 1.0-fold (0.00 log units) below, within the range that was stated.
By their numbers in this assay, from the lowest: compounds 3, 1, 4 and 2 (each within the scatter of the next, the first and the last beyond it).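

Putting 3-(trifluoromethyl)phenyl in place of 3,4-dichlorophenyl on the amide-type nitrogen gives a 1.4-fold higher number from compound 1 to compound 4 (0.14 log units; within the scatter) in this assay. For the compounds shown here, this is the first measured change of the whole aromatic group at this place, and it shows that these two substituted phenyl groups cannot be told apart on this read-out, although their substituents differ in kind and in number. No measurement shown offers an explanation for this result.

The compounds shown leave open whether a group of a different kind on this nitrogen, such as a piperidine or a phenyl ring carrying a carboxylic acid, would move the number beyond the scatter. They also leave open whether the same swap would read alike on the core of compound 2.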